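Replacing azidomethyl with 3-methoxyprop-1-yn-1-yl

The source may hold more compounds than are shown below. What is called first, only, known or untested is meant among the compounds shown, and "the series" means these compounds.

Measured so far in an ADME assay on L1210/0 cells (Mus musculus) for cytotoxicity, with a stated time of 48 h (a lower number here means a stronger inhibitor, a higher number a weaker inhibitor), as follows:
compound 1 `C=Cc1cn([C@H]2C[C@H](O)[C@@H](CO)O2)c(=O)[nH]c1=O` gives 14200 nM
compound 2 `[N-]=[N+]=NCc1cn([C@H]2C[C@H](O)[C@@H](CO)O2)c(=O)[nH]c1=O` gives 124000 nM

Compound 2 has the higher of the two numbers and is the weaker inhibitor of the pair. Going by the values given here, the only measured step is an 8.7-fold higher number from compound 1 to compound 2 (0.94 log units; beyond the scatter) and it is modest, but it lies beyond the scatter. It shows that a change of group at this place on the shared core can move the number.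

The next compound is compound 3 `COCC#Cc1cn([C@H]2C[C@H](O)[C@@H](CO)O2)c(=O)[nH]c1=O` and the change from compound 2 is 3-methoxyprop-1-yn-1-yl in place of azidomethyl on an aromatic carbon with the rest of the structure the same. Among the compounds with values here, no measured compound carries 3-methoxyprop-1-yn-1-yl, so the one measured step gives only a rough guide to size. With just two values, compound 2 marks the top of the range so far. A smaller step than the measured one is expected, toward a lower number in this assay with little confidence. The estimated move is a 2.5-fold lower number from compound 2 to compound 3 (0.39 log units; beyond the scatter) and it could prove close to the scatter. The estimate for compound 3 is 50000 nM with an expected range of 12000 nM to 200000 nM for now.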

Compound 3, half-maximal inhibitory concentration: > 200000 nM
Compound 3 gave a limit, no number; the forecaster's own chance of this, stated with the estimate: 20%; at least 4.0-fold (0.60 log units) between middle value and limit.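

In this assay compound 3 gives a limit and not a number, so this member of the series cannot be placed exactly on the scale: the limit of > 200000 nM in this assay, at which 1 of the 3 values shown sits. Replacing vinyl with 3-methoxyprop-1-yn-1-yl gives an at least 14-fold higher number from compound 1 to compound 3 (1.14 log units; beyond the scatter), and with an 8.7-fold higher number from compound 1 to compound 2 (0.94 log units; beyond the scatter) this sets vinyl apart from both other groups at this aromatic carbon, with compound 1 the strongest inhibitor of the three. Replacing azidomethyl with 3-methoxyprop-1-yn-1-yl gives an at least 1.6-fold higher number from compound 2 to compound 3 (0.20 log units; that floor lies within the scatter), so compound 2 and compound 3 cannot be ordered, and these two groups may lie close together or far apart.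

Still open, on these data alone, is whether the lower number of compound 1 belongs to vinyl alone or extends to other small carbon groups, and a plain ethynyl or a prop-1-yn-1-yl group would separate the triple bond from the methoxy end of the chain. Going by these compounds alone, also open is how an amine, a hydroxymethyl or a longer alkyl chain on the same carbon would read, since only three groups at this place can be compared here.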